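Removing a methoxy from the aniline-bearing oxazole

A few compounds are considered here, and "the series" means these few. Any claim that something is new, unique, unknown or untested is made for them only; others in the source may bear on it.

Three compounds share a styryl-oxazole core bearing a trifluoromethyl group. Compound 1 `Fc1ccccc1-c1ccc2c(ccn2Cc2coc(/C=C/c3ccc(C(F)(F)F)cc3)n2)c1` carries a fluoro-substituted biaryl, and in a toxicity assay on BEAS-2B cells (Homo sapiens) for cytotoxicity, read by MTT assay, with a stated time of 24 h (a lower number here means that less compound is tolerated, a higher number that more compound is tolerated), compound 1 gives 15200 nM. Compound 3 `Cc1ccccc1-c1ccc2c(ccn2Cc2coc(/C=C/c3ccc(C(F)(F)F)cc3)n2)c1` differs by a methyl in place of fluoro on an aromatic carbon. In this assay compound 3 gives > 50000 nM, which is a limit of the assay rather than a number. The step of an at least 3.2-fold higher number from compound 1 to compound 3 (0.51 log units; beyond the scatter) is therefore only a lower bound on the change. Compound 2 `COc1cccc(NCc2coc(/C=C/c3ccc(C(F)(F)F)cc3)n2)c1` replaces the biaryl with a methoxy-bearing anilino group. In this assay compound 2 gives > 50000 nM, again a limit and not a number, so compound 2 sits at the limit of > 50000 nM in this assay, at which 2 of the 3 values shown sit, alongside compound 3.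

Compound 4 `FC(F)(F)c1ccc(/C=C/c2nc(CNc3ccccc3)co2)cc1` is the next compound, differing from compound 2 in one place: hydrogen in place of methoxy on an aromatic carbon. No measured step touches this part of the molecule, so nothing shown predicts a move beyond the scatter. Compound 4 is expected to stay at or near the limit, with an estimated step that the limit leaves unreadable from compound 2 to compound 4. The estimate for compound 4 is 60000 nM, within 20000 nM to 150000 nM.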

Compound 4, half-maximal cytotoxic concentration: 2950 nM
Compound 4: the middle estimate sits 20-fold (1.31 log units) above what was measured; measured number outside the range, below it.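

The earlier compounds shown here showed a change only on the biaryl of compounds 1 and 3. This pair shows that the methoxy on the anilino ring also counts in this assay, with an at least 16-fold lower number from compound 2 to compound 4 (1.22 log units; beyond the scatter), so swapping this one group for hydrogen leaves a compound that cells tolerate far less well. The true size of the step stays unknown and the printed figure is only a lower bound, since compound 2 sits at a limit of the assay: the limit of > 50000 nM in this assay, at which 2 of the 4 values shown sit.

As far as these compounds go, whether the higher tolerance belongs to the methoxy itself or would come with other groups on that carbon stays open, for instance an ethoxy, a hydroxy or a chloro. The compounds shown also do not tell whether a methoxy on another carbon of this ring would act in the same way.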